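Swapping the Urea Arm for a Benzamide

A few compounds are considered here, and "the series" means these few. Any claim that something is new, unique, unknown or untested is made for them only; others in the source may bear on it.

Compound 1 `COc1cc(-c2nn(-c3cccc(NC(=O)Nc4ccc(Cl)c(Cl)c4)c3)cc2-c2ccncc2)ccc1Cl`: 1310 nM
Compound 2 `O=C(Nc1cccc(-n2cc(-c3ccncc3)c(-c3ccc(Cl)c(O)c3)n2)c1)Nc1ccc(Cl)c(Cl)c1`: 7220 nM

In a functional assay on 786-0 cells (Homo sapiens) for inhibition, read by sulforhodamine B assay, with a stated time of 48 h (on this read-out higher numbers stand for weaker inhibition of growth and lower numbers for stronger inhibition of growth), compound 1 holds the lower of the two numbers, so it is the stronger growth inhibitor of this pair. Compound 3 `COc1cc(-c2nn(-c3cccc(NC(=O)c4ccccc4)c3)cc2-c2ccncc2)ccc1Cl` keeps the core of compound 1 and changes one place: phenyl in place of (3,4-dichlorophenyl)amino on a carbonyl carbon.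

Among the measured compounds shown here, no step at that place has been measured. For the measured compounds named here, the only measured step is a 5.5-fold higher number from compound 1 to compound 2 (0.74 log units; beyond the scatter), made elsewhere in the molecule, so it offers a guide to size and not a direct precedent. A step of similar size is expected in this assay, towards a higher number, though this direction is uncertain. For compound 3 the estimated value is 3000 nM, with a range of 700 nM to 12000 nM. The estimated change is a 2.3-fold higher number from compound 1 to compound 3 (0.36 log units; beyond the scatter).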

Compound 3, concentration for 50% growth inhibition: 1520 nM
Compound 3: the middle estimate sits 2.0-fold (0.30 log units) above what was measured; the range from low to high includes it.
By their numbers in this assay, from the lowest: compounds 1 and 3 (each within the scatter of the next); then compound 2.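

In this assay, putting phenyl in place of (3,4-dichlorophenyl)amino on the carbonyl carbon turns the urea arm into a benzamide and gives a 1.2-fold higher number from compound 1 to compound 3 (0.06 log units; within the scatter), so the two compounds cannot be told apart. At this place, then, growth inhibition does not depend on keeping the two chlorine atoms or the hydrogen-bond donor of the leaving group, although both go in the same step and their separate contributions cannot be read. No measurement on hand explains why the arm can change this much with so little effect on the number.

From the compounds shown here alone, it remains open whether the phenyl ring of the benzamide could carry a group such as an amine or a carboxylic acid to give stronger inhibition, or whether a small acetyl could replace the benzoyl altogether. The effect of hydrogen in place of methyl on the oxygen is also known only with the urea arm, so it may differ with the benzamide.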